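Trifluoromethyl in place of cyano in a small amide series

A few compounds are considered here, and "the series" means these few. Any claim that something is new, unique, unknown or untested is made for them only; others in the source may bear on it.

Measured in a functional assay on MCF7 cells (Homo sapiens) for inhibition, read by MTT assay; on this read-out higher numbers stand for weaker inhibition of growth and lower numbers for stronger inhibition of growth:
Compound 1 `COc1cc2oc(-c3cccc(NC(=O)c4cccc(Br)c4)c3)cc(=O)c2c(OC)c1OC`: 6340 nM
Compound 2 `COc1cc2oc(-c3cccc(NC(=O)c4ccc([N+](=O)[O-])cc4)c3)cc(=O)c2c(OC)c1OC`: 20100 nM
Compound 3 `COc1cc2oc(-c3cccc(NC(=O)c4ccc(C#N)cc4)c3)cc(=O)c2c(OC)c1OC`: 12700 nM

Compound 3 stands within the scatter of both other compounds: a 2.0-fold higher number from compound 1 to compound 3 (0.30 log units; within the scatter), and a 1.6-fold lower number from compound 2 to compound 3 (0.20 log units; within the scatter). Compound 4 `COc1cc2oc(-c3cccc(NC(=O)c4ccc(C(F)(F)F)cc4)c3)cc(=O)c2c(OC)c1OC` carries one change: trifluoromethyl in place of cyano on an aromatic carbon. In words, this is trifluoromethyl in place of cyano on an aromatic carbon. The closest guide is the step from nitro to cyano, which also exchanges one group on an aromatic carbon and stays within the scatter. Among the compounds with values here, the only step beyond the scatter, a 3.2-fold higher number from compound 1 to compound 2 (0.50 log units; beyond the scatter), removes 3-bromophenyl, which plays no part here. No step beyond the scatter is therefore expected in this assay. The expected step is a 1.1-fold lower number from compound 3 to compound 4 (0.02 log units; within the scatter). Compound 4 is estimated at 12000 nM, with an expected range from 5500 nM to 26000 nM.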

Compound 4, concentration for 50% growth inhibition: 10600 nM
The estimate for compound 4 lay 1.1-fold (0.05 log units) above the measured number; low and high end bracket the measured number.
By their numbers in this assay, from the lowest: compounds 1, 4, 3 and 2 (each within the scatter of the next, the first and the last beyond it).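

In this assay trifluoromethyl in place of cyano gives a 1.2-fold lower number from compound 3 to compound 4 (0.08 log units; within the scatter) and trifluoromethyl in place of nitro gives a 1.9-fold lower number from compound 2 to compound 4 (0.28 log units; within the scatter) so these three groups cannot be told apart on this aromatic carbon, although trifluoromethyl counts more heavy atoms than cyano and no hydrogen-bond acceptor. Within the data shown here, the comparison with the bromo compound gives a 1.7-fold higher number from compound 1 to compound 4 (0.22 log units; within the scatter) which leaves compound 2 as the only compound beyond the scatter of compound 1. Nothing available gives a reason for these numbers.

On these data alone, whether an amine or a carboxylic acid on this carbon would give a step beyond the scatter stays open.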